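Taking one methoxy away from compound 3

The compounds below may be only part of what the source reports. "The series", "measured", "known", "first", "only" and "open" are said of these compounds alone.

Measured in a functional assay on HepG2 cells (Homo sapiens) for cytotoxicity, read by spectrophotometry, with a stated time of 72 h; a higher number here means a weaker inhibitor, a lower number a stronger inhibitor:
- Compound 1 `COc1ccc(-c2cccc(=O)n2-c2cc(OC)c(OC)c(OC)c2)cc1`: < 10 nM (a limit)
- Compound 2 `COc1ccc(-c2cccc(=O)n2-c2cc(OC)c(OC)c(OC)c2)cc1OC`: 513 nM
- Compound 3 `COc1cc(-c2cccc(=O)n2-c2cc(OC)c(OC)c(OC)c2)cc(OC)c1OC`: 5460 nM

Of the two actual numbers, the higher belongs to compound 3 at 5460 nM, and the nearest is that of compound 2 at 513 nM. Compound 1 reports only a limit, < 10 nM.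

Compound 4 `COc1ccc(-n2c(-c3cc(OC)c(OC)c(OC)c3)cccc2=O)cc1OC`, not yet measured in this assay, differs from compound 3 by hydrogen in place of methoxy on an aromatic carbon.

Among the measured compounds shown here, two measured steps bear on this change. Both are the reverse kind, methoxy in place of hydrogen on an aromatic carbon, and both fall on a different ring of the shared core. The first is an at least 51-fold higher number from compound 1 to compound 2 (1.71 log units; beyond the scatter), a size that is only a bound because of the limit of < 10 nM in this assay, at which 1 of the 3 values shown sits. The second is an 11-fold higher number from compound 2 to compound 3 (1.03 log units; beyond the scatter), and this step leads to compound 3 itself.

Since the new change runs the other way, a lower number is expected, though the different ring leaves its size uncertain. The expected change is a 6.1-fold lower number from compound 3 to compound 4 (0.78 log units; beyond the scatter). For compound 4 the estimated value is 900 nM, with an expected range from 150 nM to 5000 nM.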

Compound 4, half-maximal inhibitory concentration: 4870 nM
Estimate against measurement, compound 4: 5.4-fold (0.73 log units) below, within the range that was stated.
By their numbers in this assay, from the lowest: compound 2; then compounds 4 and 3 (each within the scatter of the next). At a limit, below all of these: compound 1.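

In this assay, hydrogen in place of methoxy on this aromatic carbon, ortho to a methoxy group and meta to a large group, gives a 1.1-fold lower number from compound 3 to compound 4 (0.05 log units; within the scatter), so at this place on the core of compound 3 the two groups are not told apart. The earlier compounds showed the exchange of hydrogen and methoxy only on the other ring, where both steps were large, and compound 4 now shows that the same exchange need not carry a large step, with the outcome differing clearly between the two cores: the same change on two cores in this assay, an at least 51-fold higher number (1.71 log units; beyond the scatter) from compound 1 to compound 2 and a 1.1-fold higher number (0.05 log units; within the scatter) from compound 4 to compound 3, at least 45-fold (1.66 log units) apart, beyond the scatter of two such steps The value of compound 1, < 10 nM, is a limit, so that gap is known only as a bound: the limit of < 10 nM in this assay, at which 1 of the 4 values shown sits.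

What a hydroxyl, a fluorine or an amine would give on this aromatic carbon remains open, since hydrogen and methoxy are the only groups shown there. Also open, going by these compounds, is whether this place stays as silent when the other ring carries fewer methoxy groups, as it does on the core of compound 1.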